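The source may hold more compounds than are shown below. What is called first, only, known or untested is meant among the compounds shown, and "the series" means these compounds.

Going by the values given here, compound 2 `O=C(CI)NCCNc1ncnc2c1ncn2[C@@H]1O[C@H](COP(=O)(O)OP(=O)(O)OP(=O)(O)O)[C@@H](O)[C@H]1O` gives 0% in an assay on isolated protein for inhibition of hexokinase-3 (Rattus norvegicus), with a stated time of 6 h, tested at 10 mM (on this read-out higher numbers stand for more inhibition at the one concentration tested (going by the name of the read-out) and lower numbers for less inhibition), the lowest of the two numbers so far; its nearest neighbour is compound 1 `O=C(CI)NCCCCCCCCNc1ncnc2c1ncn2[C@@H]1O[C@H](COP(=O)(O)OP(=O)(O)OP(=O)(O)O)[C@@H](O)[C@H]1O`, which gives 47% in this assay. Among the compounds with values here, the one measured step, a number 47 percentage points lower from compound 1 to compound 2 (beyond the scatter), is large and beyond the scatter. Compound 3 `CC(=O)NCCCCCCCCNc1ncnc2c1ncn2[C@@H]1O[C@H](COP(=O)(O)OP(=O)(O)OP(=O)(O)O)[C@@H](O)[C@H]1O` differs from compound 2 by 6-acetamidohexyl in place of ((iodomethyl)carbonyl)amino on a saturated chain carbon, two bonds along the chain from a nitrogen on an aromatic ring. Within the data shown here, this change brings back the longer chain of compound 1 while the iodine is no longer present, and for that second part no step has been measured; only the chain-length step bears on it. Because a number 47 percentage points lower from compound 1 to compound 2 (beyond the scatter) went together with the loss of the longer chain, part of that loss is expected to be recovered, but with no measured guide for the iodine the expectation stays well below compound 1. For compound 3 a rise of a number 20 percentage points higher from compound 2 to compound 3 (beyond the scatter) is expected. Compound 3 is therefore estimated at 20%, with a range from 0% to 45%.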

Compound 3, a percentage reported as inhibition, at one concentration (the size of the read-out at that concentration, not a potency): 0%
For compound 3 the middle estimate is 20 percentage points above the measured one, within the range that was stated.
By their numbers in this assay, from the lowest: compounds 2 and 3 (each within the scatter of the next); then compound 1.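

In this assay, hydrogen in place of iodo on a saturated chain carbon bound to a carbonyl carbon, with the longer chain kept, gives a number 47 percentage points lower from compound 1 to compound 3 (beyond the scatter) and is a large step. 6-acetamidohexyl in place of ((iodomethyl)carbonyl)amino gives no change at the digits printed from compound 2 to compound 3 (within the scatter), so the longer chain without iodine does not raise the read-out, and among these three compounds inhibition appears only in compound 1, which has both the longer chain and the iodo group. No measurement on hand accounts for this result.

Going by these compounds, whether chloro or bromo in place of iodo would keep the inhibition of compound 1 remains open. So does the chain length needed with the iodo group, as a butyl or a decyl chain would show.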